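This account rests on a few compounds, and the source may have more. Where it says the series, first, only, none or still open, it means among the compounds named here.

Among the compounds with values here, in a functional assay on the whole organism (strain Swiss) with Mus musculus as the target, in the maximal electroshock model, with a stated time of 1 h, at a dose of 300 mg/kg by the intraperitoneal route (a lower number here means a weaker effect, a higher number a stronger effect of the compound at the dose given), compound 3 `CCC(C(=O)N1CCN(c2cccc(C(F)(F)F)c2)CC1)N1C(=O)CCC1=O` gives 100%, the highest of the three numbers so far. Within the data shown here, compound 2 `CCC(C(=O)N1CCN(c2ccccc2F)CC1)N1C(=O)CCC1=O` gives 50% and compound 1 `CCC(C(=O)N1CCN(c2ccc(F)cc2)CC1)N1C(=O)CCC1=O` gives 25%; the only one-place step among them is a number 25 percentage points higher from compound 1 to compound 2 (beyond the scatter), a modest rise beyond the scatter. Compound 4 `CCC(C(=O)N1CCN(c2cccc(Cl)c2)CC1)N1C(=O)CCC1=O` differs from compound 3 by chloro in place of trifluoromethyl on an aromatic carbon. Among the measured compounds shown here, no measured step exchanges one group for another on the aromatic ring, so that step bears only loosely on this change, showing merely that the ring substitution can shift the read-out. Without a direct precedent, a moderate drop from the top value is expected, and the step is expected to be a number 25 percentage points lower from compound 3 to compound 4 (beyond the scatter). Compound 4 is therefore estimated at 75%, with a range from 40% to 100%.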

Compound 4, a percentage reported as activity, at one dose (the size of the read-out at that dose, not a potency): 100%
Compound 4: middle estimate off by 25 percentage points, on the low side; the range from low to high includes it.
By their numbers in this assay, from the lowest: compound 1; then compound 2; then compounds 3 and 4 (each within the scatter of the next).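

In this assay the exchange shows no change at the digits printed from compound 3 to compound 4 (within the scatter), so at this place on the aromatic ring a single chlorine atom serves as well as trifluoromethyl. The chloro compound also stands clear of both fluorophenyl compounds, with a number 50 percentage points higher from compound 2 to compound 4 (beyond the scatter) and a number 75 percentage points higher from compound 1 to compound 4 (beyond the scatter), so the high read-out is not tied to trifluoromethyl alone. No measurement here bears on why these compounds differ.

The compounds shown leave open whether a methoxy group or an amine at this place would keep the read-out. They also leave open whether compound 3 and compound 4 would separate at a lower dose.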